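A few compounds are considered here, and "the series" means these few. Any claim that something is new, unique, unknown or untested is made for them only; others in the source may bear on it.

- Compound 1: `Nc1cc(Nc2ccc(Oc3ccc(Cl)cc3)cc2)ncn1`, < 14 mL.min-1.g-1 (a limit)
- Compound 2: `Nc1ccnc(Nc2ccc(Oc3ccc(Cl)cc3)cc2)c1`, 14 mL.min-1.g-1

Going by the values given here, in an in vitro ADME assay on microsomes from liver (Homo sapiens) for metabolic stability (a lower number here means slower removal, a higher number faster removal of the compound), compound 2 gives 14 mL.min-1.g-1, the only true number so far. Compound 1 reads < 14 mL.min-1.g-1, which is a limit of the assay and not a number. Among the compounds with values here, the only other reading is thus (the limit of < 14 mL.min-1.g-1 in this assay, at which 1 of the 2 values shown sits), so nothing yet shows how far the values of this small series can spread.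

Compound 3 `Nc1cnnc(Nc2ccc(Oc3ccc(Cl)cc3)cc2)c1` has not yet been measured. It carries 5-aminopyridazin-3-yl in place of 4-aminopyridin-2-yl on a nitrogen on an aromatic ring.

Within the data shown here, one measured step bears on this change, as it swaps the same kind of amino-bearing ring at the same place: a number no lower from compound 1 to compound 2 (the limit leaves the size open). On these data alone, its size stays open, and it gives only a direction. Compound 2 reads 14 mL.min-1.g-1, and no large rise is expected here. The expected change is small, within the scatter: a 1.2-fold lower number from compound 2 to compound 3 (0.07 log units; within the scatter). For compound 3 the estimate is 12 mL.min-1.g-1, with an expected range from 6 mL.min-1.g-1 to 24 mL.min-1.g-1. A reading that is only a limit is also quite likely for this compound.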

Compound 3, intrinsic clearance in microsomes: < 14 mL.min-1.g-1
Compound 3 ended at the assay's limit; the forecaster's own chance of this, stated with the estimate: 55%; the middle value does not contradict the limit.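

In this assay, placing 5-aminopyridazin-3-yl on a nitrogen on an aromatic ring, where 4-aminopyridin-2-yl stood, gives a number no higher from compound 2 to compound 3 (the limit leaves the size open). This shows that the position accepts a ring with 2 hetero atoms and 3 hydrogen-bond acceptors in place of one with 1 hetero atom and 2 hydrogen-bond acceptors, with no rise in the number, though neither the size of this step nor the step linking compound 1 and compound 3 can be read. Going by these compounds alone, compound 2 is still the only compound with a true number, and the small series now gathers at one end of the assay's range: the limit of < 14 mL.min-1.g-1 in this assay, at which 2 of the 3 values shown sit.

On these data alone, how far compound 1 and compound 3 truly differ from compound 2 stays unknown, and so does whether the removal rate would climb clearly at all with another group at this position, such as a plain aminophenyl ring. The compounds shown also leave open what happens when the amine on the ring becomes a hydroxyl or a methylamino group, or when the chlorine on the far ring gives way to fluorine.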